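A few compounds are considered here, and "the series" means these few. Any claim that something is new, unique, unknown or untested is made for them only; others in the source may bear on it.

Measured compounds and their values:
- compound 1, `COc1ccc2c(c1)[n+]([O-])c(C(=O)N=[N+]=[N-])c(C)[n+]2[O-]`: 83.9%
- compound 2, `Cc1c(NC(=O)OC(C)C)[n+]([O-])c2cc(Cl)ccc2[n+]1[O-]`: 98.3%

Of the compounds shown here, two have been measured in a functional assay on Ehrlich cells (Mus musculus) for cytotoxicity, read by trypan blue exclusion, with a stated time of 2 h, tested at 10 ug/mL; on this read-out higher numbers stand for a weaker effect at the one concentration tested and lower numbers for a stronger effect. Compound 2 gives 98.3%, the highest of the two numbers, which here means the weaker effect at the single concentration tested. Compound 1 gives 83.9%, a lower number, and the gap between the two lies beyond the usual scatter. The two compounds differ in more than one place, so no single structural change can be tied to that gap.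

The next compound is compound 3, `COc1ccc2c(c1)[n+]([O-])c(NC(=O)OC(C)C)c(C)[n+]2[O-]`, which differs from compound 2 in one place only: methoxy in place of chloro on an aromatic carbon. Compound 1 also carries a methoxy at that place and scores lower, but it differs from compound 3 elsewhere as well, so it offers only a loose hint. On that basis the expected step from compound 2 to compound 3 is small, a number 6.3 percentage points lower from compound 2 to compound 3 (within the scatter), downward if anything, and likely within the scatter. Compound 3 is therefore estimated at 92% in this assay, with a range from 75% to 100%.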

Compound 3, a percentage reported as activity, at one concentration (the size of the read-out at that concentration, not a potency): 99%
For compound 3 the middle estimate is 7 percentage points below the measured one; low and high end bracket the measured number.
By their numbers in this assay, from the lowest: compound 1; then compounds 2 and 3 (each within the scatter of the next).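

In this assay, methoxy in place of chloro on an aromatic carbon gives a number 0.7 percentage points higher from compound 2 to compound 3 (within the scatter) and so, with the shared group of 7 heavy atoms present, this position shows no readable difference between the two groups. The step that stands out lies at the other site: a group of 7 heavy atoms in place of a group of 5 heavy atoms, on an aromatic carbon, gives a number 15.1 percentage points higher from compound 1 to compound 3 (beyond the scatter) with the methoxy held constant. Methoxy alone therefore does not go with a lower number, and the gap goes with that other group, though this rests on one pair of compounds and no measurement at hand explains either step.

Still open, as far as these compounds go, is whether chloro and methoxy would also match in a compound carrying the group of 5 heavy atoms, where the number is lower and a difference would have more room to appear. Also open, from the compounds shown here alone, is how an amine or a longer chain such as ethoxy would read on that aromatic carbon, and how a carboxylic acid would read at the other site.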